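The source may report more compounds than this note shows. Statements on the series, on what has been measured and on what is new or still open speak of the compounds shown alone.

Three analogues sharing one core have been compared in a functional assay on OVCAR-5 cells (Homo sapiens) for inhibition, read by sulforhodamine B assay, with a stated time of 48 h, tested at 10 uM; a lower number here means a stronger effect, a higher number a weaker effect of the compound at the concentration tested. Compound 1 `COc1cc(Cl)cc(-c2nn(-c3cccc(NC(=O)Nc4ccc(Cl)c(C(F)(F)F)c4)c3)cc2-c2ccncc2)c1` gives 19.2%, and compound 2 `COc1cc(Cl)cc(-c2nn(-c3cccc(NC(=O)Nc4cc(C(F)(F)F)cc(C(F)(F)F)c4)c3)cc2-c2ccncc2)c1` gives 21.7%, the two lying within the usual scatter of each other. Compound 3 `COc1cc(Cl)cc(-c2nn(-c3cccc(NC(=O)Nc4ccc(Cl)c(Cl)c4)c3)cc2-c2ccncc2)c1` gives 37.8%, the highest of the three numbers, beyond the scatter from both compound 2 and compound 1. The one measured step that joins two of these compounds at a single position, chloro in place of trifluoromethyl on an aromatic carbon, reads a number 18.6 percentage points higher from compound 1 to compound 3 (beyond the scatter) in this assay .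

Compound 4 `COc1cc(Cl)cc(-c2nn(-c3cccc(NC(=O)Nc4cccc(C(F)(F)F)c4)c3)cc2-c2ccncc2)c1` is not yet measured. It differs from compound 3 in that (3-(trifluoromethyl)phenyl in place of 3,4-dichlorophenyl on an amide-type nitrogen), so that the 3,4-dichlorophenyl leaves and a 3-(trifluoromethyl)phenyl enters on the amide-type nitrogen. The step from compound 1 to compound 3 bears on this change in reverse, since the trifluoromethyl returns, yet compound 4 also lacks a chloro that compound 1 carries, so a full reversal is not assured. Compound 4 is therefore expected to give a number lower than that of compound 3, with an estimated step of a number 10.8 percentage points lower from compound 3 to compound 4 (beyond the scatter), perhaps beyond the scatter. The estimate for compound 4 in this assay is 27%, within a range from 14% to 42%.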

Compound 4, a percentage reported as activity, at one concentration (the size of the read-out at that concentration, not a potency): 34.1%
Beside the measured number, compound 4's estimate is 7.1 percentage points below it, and the stated range covers the measured number.
By their numbers in this assay, from the lowest: compounds 1 and 2 (each within the scatter of the next); then compounds 4 and 3 (each within the scatter of the next).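

In this assay the exchange of 3,4-dichlorophenyl for 3-(trifluoromethyl)phenyl on the amide-type nitrogen reads a number 3.7 percentage points lower from compound 3 to compound 4 (within the scatter), so a lone trifluoromethyl on this aryl group cannot be told apart from the two chloro groups, even though trifluoromethyl in place of chloro had mattered in the earlier comparison. Hydrogen in place of chloro reads a number 14.9 percentage points higher from compound 1 to compound 4 (beyond the scatter), and hydrogen in place of trifluoromethyl reads a number 12.4 percentage points higher from compound 2 to compound 4 (beyond the scatter), which shows that the lower numbers among these compounds go with a trifluoromethyl accompanied by a second chloro or trifluoromethyl, with compound 3 standing against any rule that two groups of any kind on this ring are enough. Nothing available here accounts for these steps.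

The compounds shown leave open what the phenyl ring with no group on it would give, and whether a lone chloro would behave as the lone trifluoromethyl does. They also leave open whether a trifluoromethyl paired with a different partner, such as a nitrile or a dimethylamino group, would keep the lower numbers seen with a chloro or a second trifluoromethyl.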